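This account rests on a few compounds, and the source may have more. Where it says the series, first, only, none or still open, it means among the compounds named here.

The series is read in an assay on isolated protein for inhibition of glucose-6-phosphatase catalytic subunit 1 (Homo sapiens), read by inositol phosphate accumulation, with a stated time of 30 min, tested at 100 uM; a lower number here means less inhibition, a higher number more inhibition at the concentration tested (going by the name of the read-out). Among the compounds with values here, compound 1 `COc1ccc(C2C=C(c3ccccc3)NC3=C2C(=O)CCC3)cc1` gives 17.3% in this assay, one of only two numbers recorded; compound 3 `CC1(C)CC(=O)c2c(-c3ccc(Cl)cc3)cc(-c3ccccc3)nc2C1` gives 11.3%, and the gap between compound 1 and compound 3 stays within the usual scatter, so the two cannot be told apart. Compound 2 `CCOC(=O)C1(O)CC(c2ccc(F)cc2)C2=C(CC(C)(C)CC2=O)O1` is reported in this assay as "not active" (no number reported), with no number attached. Compound 4 `O=C1CCCC2=C1C(c1ccccc1)C=C(c1ccccc1)N2` has not yet been measured in this assay. It differs from compound 1 by hydrogen in place of methoxy on an aromatic carbon. Within the data shown here, no pair of measured compounds isolates this change, so nothing calibrates it; the expectation rests on compound 1 alone. Given that compound 1 itself sits at 17.3% and no entry in the series reaches high inhibition, the step from compound 1 to compound 4 is expected to be small, estimated as a number 3.3 percentage points lower from compound 1 to compound 4 (within the scatter) and not beyond the scatter, if anything a slight drift downward. For compound 4 the estimate is 14%, expected to fall between 2% and 28%.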

Compound 4, a percentage reported as inhibition, at one concentration (the size of the read-out at that concentration, not a potency): "not active" (no number reported)
Nothing numeric was reported for compound 4; there is nothing to compare the estimate with.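

In this assay, within the data shown here, compound 4 gives "not active" (no number reported) and compound 1 gives 17.3%, so no step between them can be read. Going by these compounds, whether replacing 4-methoxyphenyl with phenyl changes inhibition stays open. No supporting data bear on this result.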